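This account rests on a few compounds, and the source may have more. Where it says the series, first, only, none or still open, it means among the compounds named here.

Compound 1 `COc1ccc2c(c1)c(/C=N\NC(=O)c1c[nH]c3ccc(Br)cc13)cn2Cc1ccc(Cl)cc1` gives 29100 nM in a functional assay on MCF7 cells (Homo sapiens) for cytotoxicity; on this read-out higher numbers stand for weaker inhibition and lower numbers for stronger inhibition. Compound 2 `COc1ccc2c(c1)c(/C=N\NC(=O)c1c[nH]c3ccccc13)cn2Cc1ccc(Cl)cc1` gives 8700 nM, and the step of a 3.3-fold lower number from compound 1 to compound 2 (0.52 log units; beyond the scatter) reflects (hydrogen in place of bromo on an aromatic carbon). Compound 3 `O=C(N/N=C\c1cn(Cc2ccc(Cl)cc2)c2ccc(Br)cc12)c1c[nH]c2ccccc12` gives 3200 nM, with the step of a 2.7-fold lower number from compound 2 to compound 3 (0.43 log units; beyond the scatter) setting it lowest of the three. Compound 4 `O=C(N/N=C\c1cn(Cc2ccc(Cl)cc2)c2ccccc12)c1c[nH]c2ccccc12` has not been measured; it differs from compound 3 by hydrogen in place of bromo on an aromatic carbon, the same change seen between compound 1 and compound 2. The difference between the core of compound 3 and the core of compound 1 is not broken down here. Because compound 1 to compound 2 gave a 3.3-fold lower number from compound 1 to compound 2 (0.52 log units; beyond the scatter), a similar step of a 3.2-fold lower number from compound 3 to compound 4 (0.51 log units; beyond the scatter) is expected. Compound 4 is estimated at 1000 nM, with a range from 400 nM to 3000 nM.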

Compound 4, half-maximal inhibitory concentration: 96700 nM
The estimate for compound 4 lay 97-fold (1.99 log units) below the measured number, outside the stated range (above it).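

In this assay, hydrogen in place of bromo on an aromatic carbon did not behave alike on the two cores, and the two steps run in opposite directions: the same change on two cores in this assay, a 3.3-fold lower number (0.52 log units; beyond the scatter) from compound 1 to compound 2 and a 30-fold higher number (1.48 log units; beyond the scatter) from compound 3 to compound 4, 100-fold (2.00 log units) apart, beyond the scatter of two such steps. Compound 4 also stands apart from both of its neighbours, with a 30-fold higher number from compound 3 to compound 4 (1.48 log units; beyond the scatter) and an 11-fold higher number from compound 2 to compound 4 (1.05 log units; beyond the scatter), so among these compounds either bromo or methoxy on this core goes with a lower number than hydrogen. This shows that the step seen on one core cannot be carried over to the other in this series, but it does not show why, and two cores give no rule for any further core.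

The compounds shown leave open how an amine or a carboxylic acid would read out at that same carbon. They also leave open whether either would follow the trend of bromo and methoxy.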